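A fluoro to iodo swap near the assay limit

This account rests on a few compounds, and the source may have more. Where it says the series, first, only, none or still open, it means among the compounds named here.

In an ADME assay on BJ cells (Homo sapiens) for cytotoxicity, with a stated time of 72 h (a higher number here means that more compound is needed for the effect, a lower number that less compound is needed), compound 1 (`Cc1nn(-c2ccccc2)c2nc(-c3ccccc3)c(C#N)c(-c3ccccc3O)c12`) stands at > 23000 nM as a limit and not a number. Going by the values given here, compound 2 (`Cc1ccc(-c2nc3c(c(C)nn3-c3ccccc3)c(-c3ccccc3O)c2C#N)cc1`) gives 22200 nM as the only true number in the set. Compound 3 (`Cc1nn(-c2ccccc2)c2nc(-c3ccc(F)cc3)c(C#N)c(-c3ccccc3O)c12`) stands at > 20000 nM which is also a limit and not a number.

The next step leads to compound 4 (`Cc1nn(-c2ccccc2)c2nc(-c3ccc(I)cc3)c(C#N)c(-c3ccccc3O)c12`) and puts iodo in place of fluoro on an aromatic carbon. It turns 4-fluorophenyl to 4-iodophenyl.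

Among the compounds with values here, no measured step brings in iodo, so the guidance is indirect. Methyl in place of hydrogen gives an at least 1.0-fold lower number from compound 1 to compound 2 (0.01 log units; that floor lies within the scatter) and this offers only a floor. Fluoro in place of hydrogen gives a step that the two limits leave unreadable from compound 1 to compound 3 and fluoro in place of methyl gives a step that the limit leaves unreadable from compound 2 to compound 3 so neither adds a size. Within the data shown here, the one firm anchor is compound 2 at 22200 nM and a change at this place is therefore not expected to move the number far from that region.

The step expected is small and toward a lower number: an at least 1.1-fold lower number from compound 3 to compound 4 (0.07 log units; that floor lies within the scatter) as estimated. For compound 4 the estimated value is 17000 nM within an expected range of 7000 nM to 30000 nM and the assay may well report only a limit.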

Compound 4, half-maximal effective concentration: 19000 nM
The estimate for compound 4 lay 1.1-fold (0.05 log units) below the measured number; the range from low to high includes it.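

Going by these compounds alone, with compound 4, the position on the aromatic carbon para to a large group has a second true number in this assay, so an exchange of groups there can be read as a size for the first time: a 1.2-fold lower number from compound 2 to compound 4 (0.07 log units; within the scatter). Iodo in place of methyl therefore leaves compound 2 and compound 4 indistinguishable in this assay, even though iodine is a single heavy atom of a different element from the methyl carbon. The two steps that start from limits give only floors, an at least 1.0-fold lower number from compound 3 to compound 4 (0.02 log units; that floor lies within the scatter) and an at least 1.2-fold lower number from compound 1 to compound 4 (0.08 log units; that floor lies within the scatter), and neither floor shows a change beyond the scatter, while the value of compound 3 remains a limit and not a number: the limit of > 20000 nM in this assay, at which 1 of the 4 values shown sits.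

The four compounds differ only at this one position and carry only hydrogen, methyl, fluoro or iodo there, so they leave open whether an amine, a carboxylic acid or a longer chain at the same place would move the number beyond the scatter. They also say nothing about changes elsewhere on the shared core, such as replacing the nitrile.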